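The compounds below may be only part of what the source reports. "The series", "measured", "known", "first", "only" and "open" are said of these compounds alone.

Of the compounds shown here, three have so far been measured in an assay on isolated protein for inhibition of Rho-associated protein kinase 2 (Homo sapiens), read by scintillation counting, radiometric assay and 33P incorporation, with a stated time of 40 min, in the presence of a further agent that is not named here; on this read-out lower numbers stand for stronger inhibition and higher numbers for weaker inhibition. Compound 1 `COc1ccc(OCC(=O)Nc2cccc(NC(=O)c3ccc(N(C)C)cc3)c2)cc1F` gives 652 nM in this assay, compound 2 `CC(=O)c1ccc(OCC(=O)Nc2cccc(NC(=O)c3ccc(N(C)C)cc3)c2)cc1F` gives 98 nM, and compound 3 `CC(C)(C)c1ccc(C(=O)Nc2cccc(NC(=O)COc3ccc4c(=O)ccoc4c3)c2)cc1` gives 34 nM. Compound 3 therefore holds the lowest number of the three; its difference to compound 2 lies beyond the scatter, and its gap to compound 1 is wider still. Going by the values given here, the only step between compounds that differ in a single place is a 6.7-fold lower number from compound 1 to compound 2 (0.82 log units; beyond the scatter). That step concerns a different part of the shared core than the change considered here, so it shows only how large a single exchange of a group can be in this series, not which way the present one will go.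

Compound 4 `Nc1cccc(C(=O)Nc2cccc(NC(=O)COc3ccc4c(=O)ccoc4c3)c2)c1` has not yet been measured in this assay. It differs from compound 3 in one place: 3-aminophenyl in place of 4-(tert-butyl)phenyl on a carbonyl carbon. Among the compounds with values here, no measured pair shows what happens when the group on that carbonyl carbon is exchanged, so the direction of the change cannot be read from the numbers at hand. A modest rise in the number, toward the range of compound 2, is expected, with the step estimated as a 2.9-fold higher number from compound 3 to compound 4 (0.47 log units; beyond the scatter). Compound 4 is accordingly expected to give about 100 nM, within a range from 20 nM to 500 nM.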

Compound 4, half-maximal inhibitory concentration: 58 nM
Estimate against measurement, compound 4: 1.7-fold (0.24 log units) above; the range from low to high includes it.
By their numbers in this assay, from the lowest: compounds 3, 4 and 2 (each within the scatter of the next, the first and the last beyond it); then compound 1.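

In this assay, going by these compounds alone, the exchange on this carbonyl carbon gives a 1.7-fold higher number from compound 3 to compound 4 (0.23 log units; within the scatter) and thus no change that can be told apart from the usual scatter, so this is the first measured sign that this position can take quite different groups. The entering 3-aminophenyl has fewer heavy atoms than the leaving 4-(tert-butyl)phenyl, and it brings 1 hydrogen-bond donor and 1 hydrogen-bond acceptor where the leaving group has none, yet these differences leave no mark on the number here, unlike the earlier exchange elsewhere on the shared core, which gave a 6.7-fold lower number from compound 1 to compound 2 (0.82 log units; beyond the scatter) and lay beyond the scatter. Nothing at hand says why the two groups read alike.

Within the data shown here, only two groups have been compared at this position, so it remains open whether the amine on the ring matters at all, a question that a plain phenyl would address. As far as these compounds go, it also remains open whether a carboxylic acid or a longer chain carrying an amine on the same ring would be taken up as readily as these two groups.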